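The source may hold more compounds than are shown below. What is called first, only, known or untested is meant among the compounds shown, and "the series" means these compounds.

Compound 2 `C=CC[C@H]1C[C@]2([C@@H](C)Cc3ccc(OC)c(NC(C)=O)c3)OCOC2=CC1=O` gives 310 nM in a functional assay on NCI-H460 cells (Homo sapiens) for antiproliferative activity, with a stated time of 72 h; on this read-out lower numbers stand for stronger inhibition and higher numbers for weaker inhibition. Compound 1 `C=CC[C@H]1C[C@]2([C@@H](C)Cc3ccc(OC)cc3)OCOC2=CC1=O` gives 90 nM in this assay; the change here is hydrogen in place of acetamido on an aromatic carbon, and it made a step of a 3.4-fold lower number from compound 2 to compound 1 (0.54 log units; beyond the scatter). Compound 3 `C=CC[C@H]1C[C@]2([C@@H](C)Cc3cc(NC(C)=O)c(OC)cc3F)OCOC2=CC1=O` gives 71 nM in this assay; its core differs from that of compound 2 by fluoro in place of hydrogen on an aromatic carbon, a step of a 4.4-fold lower number from compound 2 to compound 3 (0.64 log units; beyond the scatter). Compound 4 `C=CC[C@H]1C[C@]2([C@@H](C)Cc3ccc(OC)cc3F)OCOC2=CC1=O` is not yet measured. From compound 3 to compound 4 the change is hydrogen in place of acetamido on an aromatic carbon, the same kind of change as from compound 2 to compound 1, though here the place is also para to a fluoro group. For compound 4 a step of a 2.4-fold lower number from compound 3 to compound 4 (0.37 log units; beyond the scatter) is expected in this assay, resting on the earlier step of a 3.4-fold lower number from compound 2 to compound 1 (0.54 log units; beyond the scatter) and on compound 3 at 71 nM. Compound 4 is estimated at 30 nM, with a likely range from 10 nM to 90 nM.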

Compound 4, half-maximal inhibitory concentration: 94 nM
For compound 4 the middle estimate is 3.1-fold (0.50 log units) below the measured one, and the stated range ends below it.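

In this assay, putting hydrogen in place of acetamido gives a 1.3-fold higher number from compound 3 to compound 4 (0.12 log units; within the scatter), which does not repeat the earlier step on the core without fluoro: the same change on two cores in this assay, a 3.4-fold lower number (0.54 log units; beyond the scatter) from compound 2 to compound 1 and a 1.3-fold higher number (0.12 log units; within the scatter) from compound 3 to compound 4, 4.6-fold (0.66 log units) apart, beyond the scatter of two such steps. Putting fluoro in place of hydrogen gives a 1.0-fold higher number from compound 1 to compound 4 (0.02 log units; within the scatter), which likewise does not repeat its step on the core carrying acetamido: the same change on two cores in this assay, a 4.4-fold lower number (0.64 log units; beyond the scatter) from compound 2 to compound 3 and a 1.0-fold higher number (0.02 log units; within the scatter) from compound 1 to compound 4, 4.6-fold (0.66 log units) apart, beyond the scatter of two such steps. So each change lowers the number only when it starts from compound 2, and the two changes do not simply add up, but this rests on a single set of four compounds and does not show why the steps differ.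

Going by these compounds, whether an amine or a longer acyl chain in place of acetamido would behave the same way remains open. So does the outcome with chloro in place of fluoro.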